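A Pyridyl Ring Replaces a Halogenated Phenyl Group

The compounds below may be only part of what the source reports. "The series", "measured", "known", "first", "only" and "open" are said of these compounds alone.

Three compounds have been measured in a functional assay on CHO cells with adenosine receptor A1 (Homo sapiens) as the target, read by cAMP accumulation and immunoassay, with a stated time of 6 min, tested at 0.1 uM; on this read-out lower numbers stand for a stronger effect and higher numbers for a weaker effect at the one concentration tested:

Compound 1, `Nc1scc(CN2CCN(c3ccc(F)cc3Cl)CC2)c1C(=O)c1ccc(Cl)cc1`: -6.2%
Compound 2, `Nc1scc(CN2CCN(c3ccc(Cl)cc3F)CC2)c1C(=O)c1ccc(Cl)cc1`: -9.4%
Compound 3, `Nc1scc(CN2CCN(c3ccc([N+](=O)[O-])cc3)CC2)c1C(=O)c1ccc(Cl)cc1`: -13%

All three share a core and differ only in the group on an amine nitrogen in a ring. Compound 2 has the second highest of the three numbers. Its nearest neighbour is compound 1, and the step of a number 3.2 percentage points lower from compound 1 to compound 2 (within the scatter) lies within the scatter; the step of a number 3.6 percentage points lower from compound 2 to compound 3 (within the scatter) also lies within the scatter, as does a number 6.8 percentage points lower from compound 1 to compound 3 (within the scatter). In this assay, then, the three compounds cannot be told apart.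

Compound 4, `Nc1scc(CN2CCN(c3ccncc3)CC2)c1C(=O)c1ccc(Cl)cc1`, has not yet been measured. It differs from compound 2 in a single place: pyridin-4-yl in place of 4-chloro-2-fluorophenyl on an amine nitrogen in a ring.

Within the data shown here, every measured step so far swaps one group on the amine nitrogen in a ring for another, and none of them moved the number beyond the scatter. The change to compound 4 is of the same kind, at the same place, so no step beyond the scatter is expected; the estimated step is a number 0.4 percentage points higher from compound 2 to compound 4 (within the scatter).

Compound 4 is therefore expected to give about -9% in this assay, with a likely range from -24% to 6%.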

Compound 4, a percentage reported as activity, at one concentration (the size of the read-out at that concentration, not a potency): 1.4%
Estimate against measurement, compound 4: 10.4 percentage points below; the measured number falls inside the stated range.
By their numbers in this assay, from the lowest: compounds 3, 2, 1 and 4 (each within the scatter of the next, the first and the last beyond it).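

Among these compounds, the group on the amine nitrogen in a ring can move the number after all: in this assay the pyridin-4-yl group gives a number 10.8 percentage points higher from compound 2 to compound 4 (beyond the scatter) and also a number 14.4 percentage points higher from compound 3 to compound 4 (beyond the scatter), the first steps at this position to pass beyond the scatter, though both are modest. The change does not separate compound 4 from every earlier compound, since a number 7.6 percentage points higher from compound 1 to compound 4 (within the scatter) stays within the scatter, so compound 1 and compound 4 cannot be told apart, and the picture is a small shift against two of the three aryl groups, not a clean break from all of them. Nothing measured here accounts for this shift.

The compounds shown carry a ring nitrogen only in pyridin-4-yl, so it remains open whether pyridin-3-yl, pyridin-2-yl or a plain phenyl group would give a number like that of compound 4 or like those of compound 2 and compound 3. Each number also comes from a single concentration, so how the size of these steps relates to potency is left open as well.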